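Lengthening the chain, then swapping methyl for phenyl

The source may hold more compounds than are shown below. What is called first, only, known or untested is meant among the compounds shown, and "the series" means these compounds.

Two sulfonylureas have been measured in an assay on microsomes from liver for inhibition of sterol O-acyltransferase 1 (Rattus norvegicus); a higher number here means a weaker inhibitor, a lower number a stronger inhibitor. Compound 1, `CCCCCCCCC(c1ccccc1)S(=O)(=O)NC(=O)Nc1c(C(C)C)cccc1C(C)C`, gives 9200 nM. Compound 2, `CCCCCCCCCCCCCC(C)S(=O)(=O)NC(=O)Nc1c(C(C)C)cccc1C(C)C`, gives 830 nM, the lowest of the two numbers, and the gap to compound 1 lies beyond the usual scatter. Compound 3, `CCCCCCCCCCCCCC(c1ccccc1)S(=O)(=O)NC(=O)Nc1c(C(C)C)cccc1C(C)C`, has not yet been measured. It differs from compound 2 in one place: phenyl in place of methyl on a saturated chain carbon bound to a saturated chain carbon and a sulfonyl sulfur. Within the data shown here, no measured pair shows this change alone, so its effect is unknown. Compound 1 also carries a phenyl at that position, yet it differs from compound 3 in its chain as well, so its value only hints that the phenyl may cost some potency. The step from compound 2 to compound 3 is expected to be a moderate loss, a 2.4-fold higher number from compound 2 to compound 3 (0.38 log units; beyond the scatter). Compound 3 is therefore estimated at 2000 nM in this assay, within a range of 600 nM to 7000 nM.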

Compound 3, half-maximal inhibitory concentration: 2300 nM
Compound 3: middle estimate off by 1.2-fold (0.06 log units), on the low side; the range from low to high includes it.
By their numbers in this assay, from the lowest: compound 2; then compound 3; then compound 1.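

In this assay, the exchange of methyl for phenyl on this saturated chain carbon can now be read on its own: a 2.8-fold higher number from compound 2 to compound 3 (0.44 log units; beyond the scatter), a modest loss of potency on the long chain. With phenyl kept in place, pentyl in place of hydrogen on the chain brings a 4.0-fold lower number from compound 1 to compound 3 (0.60 log units; beyond the scatter), so the longer chain carries a phenyl-bearing compound to a clearly stronger level, although that level still falls short of the methyl compound, compound 2. Nothing available explains either step.

Going by these compounds, whether a benzyl or an ethyl at this carbon would land nearer compound 2 or compound 3 remains open. On these data alone, it is also open whether a longer chain than that of compound 3 would lower the number further, and whether the cost of phenyl would be the same size on a chain of another length.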